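A few compounds are considered here, and "the series" means these few. Any claim that something is new, unique, unknown or untested is made for them only; others in the source may bear on it.

Measured so far in a functional assay on HeLa cells (Homo sapiens) for inhibition; on this read-out lower numbers stand for stronger inhibition and higher numbers for weaker inhibition
compound 1 `COc1cc(/C=C\c2cn(C(C)=O)c3ccccc23)cc(OC)c1OC` gives 2850 nM
compound 2 `COc1cc(/C=C\c2c[nH]c3ccccc23)cc(OC)c1OC` gives 3230 nM
compound 3 `COc1cc(/C=C/c2cn(C)c3ccccc23)cc(OC)c1OC` gives 3090 nM

Compound 3 lies within the scatter of both compound 1 and compound 2, so the three values do not separate in this assay. Next in line is compound 4 `COc1cc(/C=C\c2cn(C)c3ccccc23)cc(OC)c1OC`, and the change from compound 3 is this: the two compounds have the same atoms and bonds and differ only in configuration as drawn: 1 of 1 stereo elements differ; a double bond is drawn E in compound 3 and Z in compound 4. Among the compounds with values here, no measured pair isolates this change. Within the data shown here, the only measured step is a 1.1-fold higher number from compound 1 to compound 2 (0.05 log units; within the scatter), which replaces acetyl with hydrogen on an aromatic nitrogen, leaves the double bond as drawn, and stays within the scatter. Compound 1 and compound 2 are both drawn Z and still sit level with compound 3 , although they also differ from it on that nitrogen. On this limited evidence, no step beyond the scatter is expected, and no direction is favoured with any confidence. On these data alone, the estimated change is a 1.1-fold lower number from compound 3 to compound 4 (0.06 log units; within the scatter), and a wide range is kept because the double-bond change itself is untested. For compound 4 the estimated value is 2700 nM, with an expected range from 800 nM to 6000 nM.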

Compound 4, half-maximal inhibitory concentration: 3090 nM
For compound 4 the middle estimate is 1.1-fold (0.06 log units) below the measured one; the measured number falls inside the stated range.
By their numbers in this assay, from the lowest: compounds 1, 3, 4 and 2 (each within the scatter of the next).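

In this assay the double bond now has a direct test, with no change at the digits printed from compound 3 to compound 4 (within the scatter), so the forms drawn E and Z do not separate on this read-out. With the Z form held fixed, the aromatic nitrogen can also be read across three groups: a 1.0-fold lower number from compound 2 to compound 4 (0.02 log units; within the scatter) for methyl in place of hydrogen, and a 1.1-fold higher number from compound 1 to compound 4 (0.04 log units; within the scatter) for methyl in place of acetyl, so hydrogen, methyl and acetyl stay level at this position. The double-bond comparison is a clean one, as nothing else changes within the pair: the fact that compounds 3 and 4 differ only in the configuration as drawn

On these data alone, whether a longer chain, an amine or a carboxylic acid on the aromatic nitrogen would also stay level remains open. Within the data shown here, no step in these four compounds lies beyond the scatter, so which parts of the shared core affect the number is still unknown.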